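This account rests on a few compounds, and the source may have more. Where it says the series, first, only, none or still open, it means among the compounds named here.

In a functional assay on U-937 cells (Homo sapiens) for cytotoxicity, read by MTT assay, with a stated time of 24 h (a higher number here means a weaker inhibitor, a lower number a stronger inhibitor), compound 1 (`Brc1ccc(Oc2cc(Br)cc(Br)c2OCCCCCN2CCN(c3ccccc3)CC2)c(Br)c1`) gives 42.5 ug/mL, which lies within the scatter of compound 2 (`OCCCOc1c(Br)cc(Br)cc1Oc1ccc(Br)cc1Br`) at 32.3 ug/mL and of compound 3 (`CC(=O)Oc1c(Br)cc(Br)cc1Oc1ccc(Br)cc1Br`) at 32.3 ug/mL. Compound 4 (`Brc1ccc(Oc2cc(Br)cc(Br)c2OCCCCCN2CCN(C/C=C/c3ccccc3)CC2)c(Br)c1`) carries 3-phenylprop-2-en-1-yl in place of phenyl on an amine nitrogen in a ring. Among the compounds with values here, the only measured step, no change at the digits printed from compound 2 to compound 3 (within the scatter), places acetyl in place of 3-hydroxypropyl on an oxygen on an aromatic ring, so it is an indirect guide and no measured step covers this nitrogen. On that thin basis, no shift beyond the scatter is expected in this assay, in either direction. The expected step is a 1.1-fold lower number from compound 1 to compound 4 (0.05 log units; within the scatter). For compound 4 the estimated value is 38 ug/mL, with an expected range of 18 ug/mL to 75 ug/mL.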

Compound 4, half-maximal inhibitory concentration: 32.7 ug/mL
Beside the measured number, compound 4's estimate is 1.2-fold (0.07 log units) above it; measured number inside the range.
By their numbers in this assay, from the lowest: compounds 2, 3, 4 and 1 (each within the scatter of the next).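

In this assay, within the data shown here, replacing the group on the amine nitrogen in a ring gives a 1.3-fold lower number from compound 1 to compound 4 (0.11 log units; within the scatter) and provides the first measured step at this nitrogen; the earlier step concerned only an oxygen on an aromatic ring. At this position, 3-phenylprop-2-en-1-yl, with its larger carbon count and double bond outside aromatic rings, stays within the scatter of phenyl. No available evidence bears on this result.

As far as these compounds go, whether methyl or a carboxylic acid on this nitrogen would move the number beyond the scatter remains open.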